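Swapping chloro for iodo on the 4-halophenyl series

The source may report more compounds than this note shows. Statements on the series, on what has been measured and on what is new or still open speak of the compounds shown alone.

Measured in a functional assay on MCF7 cells (Homo sapiens) for antiproliferative activity, read by MTT assay, with a stated time of 48 h; on this read-out higher numbers stand for weaker inhibition and lower numbers for stronger inhibition:
- compound 1 `Oc1ccc2ccccc2c1C(Nc1nc2ccccc2s1)c1cn(-c2ccccc2)nc1-c1ccc(I)cc1`: 18900 nM
- compound 2 `COc1cccc(-c2nn(-c3ccccc3)cc2C(Nc2nc3ccc(Cl)cc3s2)c2c(O)ccc3ccccc23)c1`: 36000 nM
- compound 3 `Oc1ccc2ccccc2c1C(Nc1nc2ccc(Cl)cc2s1)c1cn(-c2ccccc2)nc1-c1ccc(Cl)cc1`: 27500 nM

Compound 3, at 27500 nM, lies within the scatter of both other compounds, so the three values do not separate.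

The next compound is compound 4 `Oc1ccc2ccccc2c1C(Nc1nc2ccc(Cl)cc2s1)c1cn(-c2ccccc2)nc1-c1ccc(I)cc1`, which differs from compound 3 at one place: iodo in place of chloro on an aromatic carbon. This is iodo in place of chloro on an aromatic carbon, or 4-chlorophenyl to 4-iodophenyl.

Within the data shown here, no measured step isolates this change. The nearest evidence is a 1.3-fold lower number from compound 2 to compound 3 (0.12 log units; within the scatter), a change of the same aromatic substituent position that stays small. Compound 1 also carries the 4-iodophenyl group and gives 18900 nM, within the scatter of compound 3. On this basis, no step beyond the scatter is expected in this assay, and no direction is favoured with confidence.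

The expected change is a 1.1-fold lower number from compound 3 to compound 4 (0.06 log units; within the scatter). Compound 4 is estimated at 24000 nM, with an expected range of 14000 nM to 42000 nM.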

Compound 4, half-maximal inhibitory concentration: 65000 nM
Compound 4: middle estimate off by 2.7-fold (0.43 log units), on the low side; the measured number lies above the stated range.
By their numbers in this assay, from the lowest: compounds 1, 3, 2 and 4 (each within the scatter of the next, the first and the last beyond it).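

In this assay, among these compounds, the change from 4-chlorophenyl to 4-iodophenyl gives a 2.4-fold higher number from compound 3 to compound 4 (0.37 log units; beyond the scatter), the first step at this position that lies beyond the scatter, and it points to weaker inhibition, so the two halogens are not interchangeable here while the chloro elsewhere on the core is kept. With 4-iodophenyl held fixed, chloro in place of hydrogen on an aromatic carbon gives a 3.4-fold higher number from compound 1 to compound 4 (0.54 log units; beyond the scatter), showing that a second site on the core also shifts the read-out modestly. Against 3-methoxyphenyl, 4-iodophenyl gives a 1.8-fold higher number from compound 2 to compound 4 (0.26 log units; within the scatter), which stays within the scatter, so that replacement does not separate the pair.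

Going by these compounds, whether a 4-bromophenyl or 4-aminophenyl group would follow the chloro or the iodo compound remains open, as does whether the iodo step recurs on the core without its chloro. Nothing measured on these compounds accounts for either step.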